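The compounds below may be only part of what the source reports. "The series", "measured", "known", "first", "only" and "open" are said of these compounds alone.

Measured in an ADME assay on MT4 cells (Homo sapiens) for cytotoxicity, read by MTT assay, with a stated time of 96 h; on this read-out lower numbers stand for higher toxicity in this test and higher numbers for lower toxicity in this test:
Compound 1 `COc1ccc(-c2nc3cc(/C(C)=N/NC(N)=S)ccc3[nH]2)cc1`: 5000 nM
Compound 2 `COc1ccc(-c2nc3cc(C(C)=O)ccc3n2C2CCCCC2)cc1`: 27000 nM
Compound 3 `C/C(=N\NC(N)=S)c1ccc2c(c1)nc(-c1ccc(Cl)cc1)n2C1CCCCC1`: 17000 nM

Compound 3, at 17000 nM, lies within the scatter of compound 2 and clearly above compound 1. Compound 4 `COc1ccc(-c2nc3cc(/C(C)=N/NC(N)=S)ccc3n2C2CCCCC2)cc1` has not yet been measured. It differs from compound 3 by methoxy in place of chloro on an aromatic carbon, para to a large group (methoxy in place of chloro on an aromatic carbon). Among the measured compounds shown here, no measured pair isolates this change. However, compound 2, which also carries 4-methoxyphenyl, gives 27000 nM, so no step beyond the scatter is expected in this assay. The expected size of the change is a 1.1-fold lower number from compound 3 to compound 4 (0.03 log units; within the scatter). For compound 4 the estimated value is 16000 nM, with an expected range of 7000 nM to 36000 nM.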

Compound 4, half-maximal cytotoxic concentration: 39000 nM
Beside the measured number, compound 4's estimate is 2.4-fold (0.39 log units) below it; the whole stated range lies below it.
By their numbers in this assay, from the lowest: compound 1; then compounds 3, 2 and 4 (each within the scatter of the next, the first and the last beyond it).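

In this assay methoxy in place of chloro on an aromatic carbon, para to a large group, gives a 2.3-fold higher number from compound 3 to compound 4 (0.36 log units; beyond the scatter) and so moves the number at this position by a modest step beyond the scatter. Cyclohexyl in place of hydrogen on an aromatic nitrogen gives a 7.8-fold higher number from compound 1 to compound 4 (0.89 log units; beyond the scatter) as a second modest step beyond the scatter, whereas the group of 7 heavy atoms in place of the group of 3 gives a 1.4-fold higher number from compound 2 to compound 4 (0.16 log units; within the scatter) and stays within it. No evidence bearing on the reason for these steps is available.

Going by these compounds, whether the step at this position extends to fluoro, an amine or a carboxylic acid remains open. Also open, on these data alone, is how methyl or a longer chain would compare with cyclohexyl on the aromatic nitrogen.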